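Replacing 1-benzothiophen-5-yl with 1,3-benzoxazol-5-yl on a shared core

The compounds below may be only part of what the source reports. "The series", "measured", "known", "first", "only" and "open" are said of these compounds alone.

In an ADME assay (liver) for metabolic stability, with Liver microsome (Homo sapiens) as the target, using microsomes and NADPH, with a stated time of 30 min, tested at 1 uM (a lower number here means slower removal, a higher number faster removal of the compound), compound 1 `COc1ccc(-c2cc(C(O)(C(F)(F)F)C(F)(F)F)cnc2N2CCN(S(=O)(=O)c3ccc(N)nc3)CC2)cn1` gives 25 mL.min-1.g-1 and compound 2 `Nc1ccc(S(=O)(=O)N2CCN(c3ncc(C(O)(C(F)(F)F)C(F)(F)F)cc3-c3ccc4sccc4c3)CC2)cn1` gives 48 mL.min-1.g-1. Within the data shown here, these are the only two measurements so far, and they lie within the usual scatter of each other, so the numbers do not separate compound 2 from compound 1.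

Compound 3 `Nc1ccc(S(=O)(=O)N2CCN(c3ncc(C(O)(C(F)(F)F)C(F)(F)F)cc3-c3ccc4ocnc4c3)CC2)cn1` keeps the rest of compound 2 and alters one group on an aromatic carbon: 1,3-benzoxazol-5-yl in place of 1-benzothiophen-5-yl on an aromatic carbon. Among the measured compounds shown here, the only measured exchange at this place is a 1.9-fold higher number from compound 1 to compound 2 (0.28 log units; within the scatter), where 1-benzothiophen-5-yl took the place of 6-methoxypyridin-3-yl. That single step stayed within the scatter, so no step beyond the scatter is expected in this assay. There is a slight lean towards a lower number, as the entering group holds nitrogen and oxygen, like the group of compound 1 at 25 mL.min-1.g-1, though one pair is thin evidence. The expected size of the change is a 1.5-fold lower number from compound 2 to compound 3 (0.16 log units; within the scatter). The estimate for compound 3 is 33 mL.min-1.g-1, with an expected range of 16 mL.min-1.g-1 to 65 mL.min-1.g-1.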

Compound 3, intrinsic clearance in microsomes: < 14 mL.min-1.g-1
Compound 3 was reported as a limit; the forecaster's own chance of this, stated with the estimate: 5%; at least 2.3-fold (0.37 log units) between middle value and limit.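

At this position, on an aromatic carbon ortho to a large group, the exchange now gives a step beyond the scatter in this assay: with both groups holding 9 heavy atoms and the same two ring sizes, 1,3-benzoxazol-5-yl in place of 1-benzothiophen-5-yl gives an at least 3.4-fold lower number from compound 2 to compound 3 (0.53 log units; beyond the scatter). Compound 3 is reported only as a limit, < 14 mL.min-1.g-1, so this step is a floor and not an exact size: the limit of < 14 mL.min-1.g-1 in this assay, at which 1 of the 3 values shown sits. Set against 6-methoxypyridin-3-yl, the same entering group gives an at least 1.7-fold lower number from compound 1 to compound 3 (0.25 log units; that floor lies within the scatter), so the data shown do not separate this pair.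

Going by these compounds, it remains open whether the nitrogen, the oxygen or both in the entering group go with the step, a question that 1-benzofuran-5-yl, with oxygen alone in its five-membered ring, and 1,3-benzothiazol-5-yl, with sulfur and nitrogen, could help to answer. On these data alone, it is also open whether the same exchange would give a similar step if the other groups on the shared core were different.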